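The source may hold more compounds than are shown below. What is called first, only, known or untested is meant among the compounds shown, and "the series" means these compounds.

Among the compounds with values here, compound 2 `O=C(Nc1ccc(Oc2ccnc3[nH]ccc23)c(F)c1)c1nn(-c2ccc(Br)cc2F)ccc1=O` is the only compound here with a full number. In a functional assay on HepG2 cells (Homo sapiens) for cytotoxicity, read by MTT assay, with a stated time of 72 h (a higher number here means a weaker inhibitor, a lower number a stronger inhibitor), compound 2 gives 56500 nM. The other measured compound, compound 1 `O=C(Nc1ccc(Oc2ccnc3[nH]ccc23)c(F)c1)c1nn(-c2ccc(Cl)cc2)ccc1=O`, carries a 4-chlorophenyl group on the same aromatic nitrogen. In this assay compound 1 reaches only a limit, > 60000 nM, and not a number. The step of an at least 1.0-fold lower number from compound 1 to compound 2 (0.02 log units; that floor lies within the scatter) is the only measured one and lies within the scatter; with the limit of > 60000 nM in this assay, at which 1 of the 2 values shown sits, it can be read only as a floor. Compound 3 `O=C(Nc1ccc(Oc2ccnc3[nH]ccc23)c(F)c1)c1nn(-c2ccc(Cl)c(F)c2)ccc1=O` is not yet measured. It differs from compound 2 by 4-chloro-3-fluorophenyl in place of 4-bromo-2-fluorophenyl on an aromatic nitrogen. Within the data shown here, the one measured step bears on this change, since it too swapped one substituted phenyl for another and gave nothing beyond the scatter. The step of a 1.1-fold higher number from compound 2 to compound 3 (0.03 log units; within the scatter) is therefore expected to be small. Compound 3 is estimated at 60000 nM, between 25000 nM and 150000 nM, with a fair chance that only a limit is returned.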

Compound 3, half-maximal inhibitory concentration: 9610 nM
Compound 3: the middle estimate sits 6.2-fold (0.80 log units) above what was measured, and the stated range ends above it.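

Within the data shown here, the phenyl group on the aromatic nitrogen is not as forgiving as the first pair suggested: in this assay, swapping one halogen pattern for another now gives a 5.9-fold lower number from compound 2 to compound 3 (0.77 log units; beyond the scatter), the first change here beyond the scatter. The closest comparison is the single fluoro in place of hydrogen on the 4-chlorophenyl group, which gives an at least 6.2-fold lower number from compound 1 to compound 3 (0.79 log units; beyond the scatter), showing that one small atom on this ring can shift the number. That step is only a floor because compound 1 stands at a limit and not at a number: the limit of > 60000 nM in this assay, at which 1 of the 3 values shown sits.

Compound 2 and compound 3 differ both in the halogen and in where the fluoro sits, so the compounds shown cannot separate these two changes. Going by these compounds, it also remains open how this ring would behave with a methoxy group or an amine in place of the halogen.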